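A few compounds are considered here, and "the series" means these few. Any claim that something is new, unique, unknown or untested is made for them only; others in the source may bear on it.

Measured so far:
Compound 1 `C=CS(=O)(=O)c1cc(C(F)(F)F)cc(C(F)(F)F)c1`: in an ADME assay for pharmacokinetics, read by LC-MS, in phosphate buffer, with a stated time of 72 h, at pH 7.4, tested at 250 uM (a lower number here means that the compound disappears faster, a higher number that the compound lasts longer), compound 1 gives < 0.017 h, which is a limit of the assay.
Compound 2 `C#Cc1cc(C(F)(F)F)cc(C(F)(F)F)c1`: in this assay compound 2 gives > 50 h, which is also a limit of the assay.

Compound 2 stands at the limit of > 50 h in this assay, at which 1 of the 2 values shown sits, so only a limit is known for it, as for the other value shown. For the measured compounds named here, the single measured step, an at least 2900-fold higher number from compound 1 to compound 2 (3.46 log units; beyond the scatter), is large and concerns a different exchange. Compound 3 `N#Cc1cc(C(F)(F)F)cc(C(F)(F)F)c1` differs from compound 2 by cyano in place of ethynyl on an aromatic carbon. Going by the values given here, no measured step swaps these two groups, and both keep one triple bond outside aromatic rings. Compound 3 is expected to stay long-lived, with a step that the limit leaves unreadable from compound 2 to compound 3, no step beyond the scatter, and an estimated 100 h (range 30 h to 500 h).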

Compound 3, half-life: > 50 h
Compound 3 ended at the assay's limit (the forecaster's own chance of this, stated with the estimate: 85%); the middle value is on the limit's open side.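

Cyano in place of vinylsulfonyl on this aromatic carbon gives an at least 2900-fold higher number from compound 1 to compound 3 (3.46 log units; beyond the scatter), so this large rise is not unique to the ethynyl group. In this assay compound 3 gives > 50 h, which is a limit of the assay. Compound 2 also sits at a limit, so the step between these two cannot be read and neither group can be placed ahead of the other.

On these data alone, it remains open how long compound 2 and compound 3 really last. As far as these compounds go, it is also open whether a methylsulfonyl group on this carbon, which keeps the sulfonyl without the vinyl, would disappear quickly like compound 1 or last like these two.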